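A few compounds are considered here, and "the series" means these few. Any claim that something is new, unique, unknown or untested is made for them only; others in the source may bear on it.

Measured compounds:
- compound 1 `Cc1ccc(NC2=CC(=O)c3nc4n(c3C2=O)[C@H]2OC[C@@H](O)[C@H]2OC4)cc1C` gives 2820 nM in a functional assay on ECa-109 cells for inhibition, with ECa-109 cell line (Homo sapiens) as the target, read by sulforhodamine B assay; on this read-out lower numbers stand for stronger inhibition and higher numbers for weaker inhibition
- compound 2 `O=C1C(Nc2cccc(Cl)c2)=CC(=O)c2c1nc1n2[C@H]2OC[C@@H](O)[C@H]2OC1` gives 3080 nM
- compound 3 `Cc1ccc(NC2=CC(=O)c3c(nc4n3[C@H]3OC[C@@H](O)[C@H]3OC4)C2=O)cc1C` gives 4090 nM

Compound 1 has the lowest of the three numbers, but its nearest neighbour is compound 2, whose value stands within the scatter, and compound 3 also lies within the scatter of compound 1. The three measured compounds thus sit together on one level, and none can be called stronger or weaker than another.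

Compound 4 `O=C1C=C(NC2CCCCC2)C(=O)c2c1nc1n2[C@H]2OC[C@@H](O)[C@H]2OC1` has not been measured. It differs from compound 1 in one place: cyclohexyl in place of 3,4-dimethylphenyl on an amine nitrogen. For the measured compounds named here, the only step recorded among the measured compounds, a 1.3-fold higher number from compound 2 to compound 3 (0.12 log units; within the scatter), exchanges one six-membered aromatic ring for another and stays within the scatter. Going by the values given here, no measured step exchanges an aromatic ring for a non-aromatic one at this amine nitrogen, so nothing directly bears on the move to cyclohexyl. Given that the three measured values cluster closely, a modest shift, if any, is expected; the direction cannot be read from the data, so the estimate is placed near compound 1 with a wide range.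

Compound 4 is therefore expected to give about 4000 nM, between 1400 nM and 12000 nM, corresponding to an estimated step of a 1.4-fold higher number from compound 1 to compound 4 (0.15 log units; within the scatter).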

Compound 4, half-maximal inhibitory concentration: > 16000 nM
Compound 4 was reported as a limit; the forecaster's own chance of this, stated with the estimate: 10%; middle value at least 4.0-fold (0.60 log units) from the limit.
By their numbers in this assay, from the lowest: compounds 1, 2 and 3 (each within the scatter of the next). At a limit, above all of these: compound 4.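

In this assay, the change from 3,4-dimethylphenyl to cyclohexylamino's ring on the amine nitrogen gives an at least 5.6-fold higher number from compound 1 to compound 4 (0.75 log units; beyond the scatter), so this position does respond to what is attached there, whereas the exchange of one aromatic ring for another in a 1.3-fold higher number from compound 2 to compound 3 (0.12 log units; within the scatter) stayed within the scatter. Compound 4 gives > 16000 nM, which is a limit of the assay and not a number, so the step marks only the smallest size the change can have: the limit of > 16000 nM in this assay, at which 1 of the 4 values shown sits. Among the compounds shown, the one with a non-aromatic ring on this nitrogen lies apart from the three with an aromatic ring, whose values sit within the scatter of each other.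

Cyclohexyl differs from 3,4-dimethylphenyl both in its ring and in lacking the two methyl groups, and the compounds shown do not separate these two parts of the change; an unsubstituted phenyl or a 3,4-dimethylcyclohexyl group would bear on that. Also open, from the compounds shown here alone, is whether a benzyl group or a short chain such as ethyl on this nitrogen would sit with compound 1 or with compound 4.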